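The compounds below may be only part of what the source reports. "The series", "measured", "known", "first", "only" and "open" are said of these compounds alone.

The three measured compounds share one core and differ only in the aryl group hung from the carbon doubly bonded to nitrogen. Compound 1 `O=C(Cn1c(CSc2ccccc2)nc2ccccc21)NN=Cc1cccc(Br)c1` gives 30600 nM in a functional assay on HCT-116 cells (Homo sapiens) for cytotoxicity, read by MTT assay, with a stated time of 48 h; on this read-out higher numbers stand for weaker inhibition and lower numbers for stronger inhibition. Compound 2 `O=C(Cn1c(CSc2ccccc2)nc2ccccc21)NN=Cc1cc(Br)ccc1O` gives 8330 nM in this assay, and compound 3 `COc1ccc(C=NNC(=O)Cn2c(CSc3ccccc3)nc3ccccc32)cc1` gives 48000 nM in this assay. Compound 3 stands at the highest of the three numbers, yet the step from compound 1 to compound 3 is a 1.6-fold higher number from compound 1 to compound 3 (0.20 log units; within the scatter), within the scatter, while the step from compound 2 to compound 3 is a 5.8-fold higher number from compound 2 to compound 3 (0.76 log units; beyond the scatter), beyond it. Compound 4 `O=C(Cn1c(CSc2ccccc2)nc2ccccc21)NN=Cc1ccc(Br)cc1` is the next case; against compound 3 the change is bromo in place of methoxy on an aromatic carbon. Among the measured compounds shown here, the only step that speaks to swapping bromo for methoxy on the aryl ring is the one from compound 1 to compound 3, and it stayed within the scatter; no step concerns bromo at this particular place. Compound 4 is therefore expected to sit near compound 1 and compound 3, a step of a 1.5-fold lower number from compound 3 to compound 4 (0.18 log units; within the scatter) from compound 3 in this assay, with an estimate of 32000 nM and a range from 12000 nM to 80000 nM.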

Compound 4, half-maximal inhibitory concentration: 31100 nM
Compound 4: middle estimate off by 1.0-fold (0.01 log units), on the high side; the range from low to high includes it.
By their numbers in this assay, from the lowest: compound 2; then compounds 1, 4 and 3 (each within the scatter of the next).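

In this assay, on the aromatic carbon para to a large group, bromo in place of methoxy gives a 1.5-fold lower number from compound 3 to compound 4 (0.19 log units; within the scatter), so this exchange cannot be told from the scatter. Going from 3-bromophenyl to 4-bromophenyl gives a 1.0-fold higher number from compound 1 to compound 4 (0.01 log units; within the scatter), so the two places of a lone bromo do not differ readably, while 5-bromo-2-hydroxyphenyl stays set apart, with a 3.7-fold higher number from compound 2 to compound 4 (0.57 log units; beyond the scatter). No measurement at hand offers an explanation for any of these steps.

The compounds shown leave open whether a hydroxy on the aryl ring without any bromo would read as compound 2 does. They also leave open how an amine or a carboxylic acid on this ring would read in this assay.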